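Replacing dipropylamino with (3-fluorophenyl)amino on the shared core

The compounds below may be only part of what the source reports. "The series", "measured", "known", "first", "only" and "open" are said of these compounds alone.

Measured in a functional assay on MCF7 cells (Homo sapiens) for inhibition, read by sulforhodamine B assay; a higher number here means a weaker inhibitor, a lower number a stronger inhibitor:
- Compound 1 `COc1ccccc1NC1=CC(=O)c2c(nc3n2[C@H]2OC[C@@H](O)[C@H]2OC3)C1=O`: 6580 nM
- Compound 2 `COc1cccc(NC2=CC(=O)c3c(nc4n3[C@H]3OC[C@@H](O)[C@H]3OC4)C2=O)c1`: 3830 nM
- Compound 3 `CCCN(CCC)C1=CC(=O)c2c(nc3n2[C@H]2OC[C@@H](O)[C@H]2OC3)C1=O`: > 16000 nM, a limit and not a number

Compound 3 stands at the limit of > 16000 nM in this assay, at which 1 of the 3 values shown sits, so it has a limit and no exact value. The next compound, compound 4 `O=C1C(Nc2cccc(F)c2)=CC(=O)c2c1nc1n2[C@H]2OC[C@@H](O)[C@H]2OC1`, differs from it as follows: (3-fluorophenyl)amino in place of dipropylamino on a double-bonded ring carbon. In words, this is (3-fluorophenyl)amino in place of dipropylamino on a double-bonded ring carbon.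

Among the measured compounds shown here, two measured steps bear on this change, both running in the opposite direction. Dipropylamino in place of (2-methoxyphenyl)amino gave an at least 2.4-fold higher number from compound 1 to compound 3 (0.38 log units; beyond the scatter). Dipropylamino in place of (3-methoxyphenyl)amino gave an at least 4.1-fold higher number from compound 2 to compound 3 (0.62 log units; beyond the scatter). The two methoxyphenyl compounds themselves do not separate, with a 1.7-fold lower number from compound 1 to compound 2 (0.24 log units; within the scatter). For the measured compounds named here, no fluorophenyl compound has yet been measured, so the estimate borrows from these two neighbours, compound 1 at 6580 nM and compound 2 at 3830 nM.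

A lower number is therefore expected in this assay, of at least modest size. The estimated change is an at least 3.5-fold lower number from compound 3 to compound 4 (0.55 log units; beyond the scatter). The expected value for compound 4 is 4500 nM, with an estimated range of 2000 nM to 10000 nM.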

Compound 4, half-maximal inhibitory concentration: > 4000 nM
Compound 4 gave a limit, no number; the forecaster's own chance of this, stated with the estimate: 8%; the middle value lies beyond the limit too.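

In this assay, compound 4 gives only a limit and not a number, so the (3-fluorophenyl)amino group on this double-bonded ring carbon cannot be given an exact place among the compounds shown: the limit of > 4000 nM in this assay, at which 1 of the 4 values shown sits.

Fluoro in place of methoxy on an aromatic carbon gave an at least 1.0-fold higher number from compound 2 to compound 4 (0.01 log units; that floor lies within the scatter), so this change on the phenyl ring shows neither a real loss nor an equal result. The steps from compound 3 to compound 4 and from compound 1 to compound 4 cannot be read, which means the data do not show whether (3-fluorophenyl)amino improves on dipropylamino, as both methoxyphenyl compounds do.

As far as these compounds go, the true standing of compound 4 against compound 1, compound 2 and compound 3 therefore remains open, as does whether fluoro on the phenyl ring matters at all in this assay. Also open, from the compounds shown here alone, is how a plain phenylamino group, a 3-chlorophenylamino group or a cyclic amine such as morpholine would fare at this position on the shared core.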